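This account rests on a few compounds, and the source may have more. Where it says the series, first, only, none or still open, it means among the compounds named here.

Measured in an ADME assay on microsomes from liver (Mus musculus) for metabolic stability, read by LC-MS, with a stated time of 1 h, tested at 5 uM; a higher number here means that more of the compound is left, a lower number that less of the compound is left:
- compound 1 `Cc1nc(-c2ccccc2F)c(C(=O)N2CCN(c3cc(Cl)cc(Cl)c3)CC2)o1`: 49%
- compound 2 `COc1cc(OC)cc(N2CCN(C(=O)c3oc(C)nc3-c3ccccc3F)CC2)c1`: 16.6%

Of these two, compound 2 stands lowest, at 16.6%. Compound 3 `COc1cc(OC)cc(N2CCN(C(=O)c3oc(C)nc3-c3cccc(F)c3)CC2)c1` is the next to be read: 3-fluorophenyl in place of 2-fluorophenyl on an aromatic carbon, with 3-fluorophenyl in place of 2-fluorophenyl on an aromatic carbon. Among the measured compounds shown here, the only measured step, a number 32.4 percentage points lower from compound 1 to compound 2 (beyond the scatter), is large but lies at a different place, on an amine nitrogen in a ring. For the measured compounds named here, no measured step covers the new change, so no step beyond the scatter in this assay is expected. The estimated step is a number 0.6 percentage points lower from compound 2 to compound 3 (within the scatter). For compound 3 the expected value is 16%, with an estimated range of 6% to 32%.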

Compound 3, percent of the compound remaining: 11.6%
Compound 3: the middle estimate sits 4.4 percentage points above what was measured; low and high end bracket the measured number.
By their numbers in this assay, from the lowest: compounds 3 and 2 (each within the scatter of the next); then compound 1.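

With the 3,5-dimethoxyphenyl group held constant, 3-fluorophenyl in place of 2-fluorophenyl on the five-membered aromatic ring gives a number 5 percentage points lower from compound 2 to compound 3 (within the scatter) in this assay and so shows no difference beyond the scatter. At this position, the place of the fluorine on the phenyl ring therefore does not separate these two compounds. Nothing available bears on why the values stay together.

On these data alone, whether the same change behaves alike with the 3,5-dichlorophenyl group remains open. So does the effect of an unsubstituted phenyl or a pyridine ring at this position.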